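Series notes: sulfamoyl in place of trifluoromethyl

A few compounds are considered here, and "the series" means these few. Any claim that something is new, unique, unknown or untested is made for them only; others in the source may bear on it.

Measured so far:
compound 1 `N#CC1CN1C(=O)Nc1ccc([N+](=O)[O-])cc1` — 4300 nM
compound 2 `N#CC1CN1C(=O)Nc1ccc(C(F)(F)F)cc1` — 1300 nM

Of the compounds shown here, two of the shared core have been measured in a functional assay on WiDr cells (Homo sapiens) for inhibition; a lower number here means a stronger inhibitor, a higher number a weaker inhibitor. Compound 1 gives 4300 nM and compound 2 gives 1300 nM. Among the compounds with values here, the only step measured within the set is a 3.3-fold lower number from compound 1 to compound 2 (0.52 log units; beyond the scatter). Compound 2 therefore stands at the lowest of the two numbers, with compound 1 as its nearest neighbour at a higher number.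

Compound 3 `N#CC1CN1C(=O)Nc1ccc(S(N)(=O)=O)cc1` has not been measured. It differs from compound 2 in one place: sulfamoyl in place of trifluoromethyl on an aromatic carbon. Within the data shown here, no measured step covers this exchange directly. Among the measured compounds shown here, the single step available, a 3.3-fold lower number from compound 1 to compound 2 (0.52 log units; beyond the scatter), concerns a different pair of groups at the same place and shows that a change there shifts this assay by a modest amount. Nothing measured tells the direction for sulfamoyl, so the expectation is a shift of similar size, with a wide range that allows either direction. Compound 3 is expected to give 3000 nM, in the range 900 nM to 10000 nM. The expected step is a 2.3-fold higher number from compound 2 to compound 3 (0.36 log units; beyond the scatter).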

Compound 3, half-maximal inhibitory concentration: > 38000 nM
Compound 3: no number, only a limit; the forecaster's own chance of this, stated with the estimate: 10%; middle value at least 12-fold (1.10 log units) from the limit.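

In this assay compound 3 is recorded only as a limit: the limit of > 38000 nM in this assay, at which 1 of the 3 values shown sits.

Sulfamoyl in place of trifluoromethyl brings an at least 29-fold higher number from compound 2 to compound 3 (1.46 log units; beyond the scatter), and sulfamoyl in place of nitro brings an at least 8.8-fold higher number from compound 1 to compound 3 (0.94 log units; beyond the scatter). The exchange of nitro for trifluoromethyl had shown only a modest change at this aromatic carbon, a 3.3-fold lower number from compound 1 to compound 2 (0.52 log units; beyond the scatter), whereas this position can also carry a large loss in this assay. Among the three groups shown, sulfamoyl goes with the weakest reading, and in the exchange from compound 2 it brings in a hydrogen-bond donor and hydrogen-bond acceptors that trifluoromethyl does not have, although these counts alone do not identify what drives the loss.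

Going by these compounds, the true size of the loss stays open, since the reading for compound 3 has no upper end. The compounds shown also leave open whether the donor hydrogens of sulfamoyl matter, which a methylsulfonyl or dimethylsulfamoyl group at this place would test, and how an amine or a carboxylic acid there would read.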